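The compounds below may be only part of what the source reports. "The series", "measured", "known", "first", "only" and "open" are said of these compounds alone.

Compounds 1, 2 and 3 share one core and differ only in the aromatic group attached to it. Compound 1 `COc1cc(-c2cccc3nc(-c4ccccc4)oc23)cc(OC)c1OC` carries a phenyl group there, compound 2 `COc1ccc(-c2nc3cccc(-c4cc(OC)c(OC)c(OC)c4)c3o2)cc1F` a 3-fluoro-4-methoxyphenyl group, and compound 3 `COc1cc(-c2cccc3nc(-c4ccc(C)cc4)oc23)cc(OC)c1OC` a 4-methylphenyl group. All were tested in a functional assay on MCF7 cells (Homo sapiens) for antiproliferative activity, read by MTT assay, with a stated time of 48 h; on this read-out lower numbers stand for stronger inhibition and higher numbers for weaker inhibition. In this assay compound 1 gives > 25000 nM, which is a limit of the assay and not a number. Compound 2 likewise reaches only the limit of > 25000 nM. Compound 3 also stops at the limit of > 25000 nM. Because every value shown sits at the limit of > 25000 nM in this assay, at which 3 of the 3 values shown sit, the steps a step that the two limits leave unreadable from compound 1 to compound 2, a step that the two limits leave unreadable from compound 1 to compound 3 and a step that the two limits leave unreadable from compound 2 to compound 3 cannot be sized: compound 2 stands at the limit, like its two neighbours. Compound 4 `COc1cc(-c2cccc3nc(-c4cccc(C)c4)oc23)cc(OC)c1OC` has not yet been measured; it differs from compound 2 by 3-methylphenyl in place of 3-fluoro-4-methoxyphenyl on an aromatic carbon. The measured steps bear on this change only by showing that no variation of this aromatic group produced a readable number, so no step beyond the scatter is expected; the change is estimated as a step that the limit leaves unreadable from compound 2 to compound 4. Compound 4 is expected to give about 40000 nM, between 15000 nM and 120000 nM, most likely again only a limit.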

Compound 4, half-maximal inhibitory concentration: > 25000 nM
Compound 4: a limit, no number (the forecaster's own chance of this, stated with the estimate: 85%); the middle value does not contradict the limit.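

Among the compounds shown here, compound 4 also gives only a limit, not a number, so no step between compound 4 and compound 1, compound 2 or compound 3 can be read: the limit of > 25000 nM in this assay, at which 4 of the 4 values shown sit. The compounds shown leave open how strongly each acts and whether any aromatic group at this place would give a readable number.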